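The source may hold more compounds than are shown below. What is called first, only, known or untested is meant among the compounds shown, and "the series" means these compounds.

In an ADME assay on the whole organism (plasma) for metabolic stability, with Cynomolgus monkey (Macaca fascicularis) as the target, read by HPLC, at a dose of 30 mg/kg by the oral route (on this read-out higher numbers stand for a longer-lived compound and lower numbers for a shorter-lived compound), compound 1 (`CC(CC(=O)O)CC(=O)c1c(CCCCCCc2ccccc2)n(C)c2ccc(Cl)cc12`) gives 7.4 h as the higher of two numbers, while compound 2 (`CC(CC(=O)O)CC(=O)n1c(CCCCCc2ccccc2)cc2ccc(Cl)cc21`) gives 3 h in the same read-out. Not yet measured, compound 3 (`C[C@H](CC(=O)O)CC(=O)c1c(CCCCCCc2ccccc2)n(C)c2ccc(Cl)cc12`) shows the two compounds have the same atoms and bonds; at least one stereo element is drawn with a configuration in one of them and without one in the other: 1 of 1 stereo elements differ; a stereocentre at a saturated chain carbon is drawn without a configuration in compound 1 and S in compound 3 against compound 1, so that a stereocentre at a saturated chain carbon is drawn without a configuration in compound 1 and S in compound 3. Among the compounds with values here, no measured pair shows this kind of change, and no step beyond the scatter is expected in this assay here. The expected step is small (a 1.0-fold higher number from compound 1 to compound 3 (0.01 log units; within the scatter)). Compound 3 is estimated to give 7.5 h with 4 h to 14 h as the expected range.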

Compound 3, half-life: 3.5 h
Estimate against measurement, compound 3: 2.1-fold (0.33 log units) above; the whole stated range lies above it.
By their numbers in this assay, from the lowest: compounds 2 and 3 (each within the scatter of the next); then compound 1.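

In this assay, within the data shown here, the saturated chain carbon gives the first pair that differs at a single place, with a 2.1-fold lower number from compound 1 to compound 3 (0.33 log units; beyond the scatter). Atoms and bonds stay the same, so the drawn stereocentre alone separates the two numbers: the fact that one of compounds 1 and 3 is drawn with a defined configuration and the other without, at the place where they differ. The earlier compounds shown here offered no such reading at this stereocentre.

Going by these compounds, what the R configuration at this carbon would give remains open, as does what compound 1, drawn without a configuration, holds at that centre. Also open, on these data alone, is how an ethyl group at this stereocentre would read.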